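Swapping a furanoyl amide for a bromophenyl sulfonamide

The source may report more compounds than this note shows. Statements on the series, on what has been measured and on what is new or still open speak of the compounds shown alone.

Of the compounds shown here, two sharing one core have been measured so far. Compound 1 `CN(C(=O)c1ccc(Cl)cc1)c1ccc2[nH]c(-c3n[nH]c4ccccc34)cc2n1` gives 3000 nM in a functional assay on HCT-116 cells (Homo sapiens) for antiproliferative activity, read by MTT assay, with a stated time of 72 h; on this read-out higher numbers stand for weaker inhibition and lower numbers for stronger inhibition; compound 2 `CN(C(=O)c1ccco1)c1ccc2[nH]c(-c3n[nH]c4ccccc34)cc2n1` gives 30000 nM in this assay. Within the data shown here, compound 2 therefore holds the higher of the two numbers, the only step recorded being a 10-fold higher number from compound 1 to compound 2 (1.00 log units; beyond the scatter).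

Compound 3 `CN(c1ccc2[nH]c(-c3n[nH]c4ccccc34)cc2n1)S(=O)(=O)c1ccc(Br)cc1` is the next member. It differs from compound 2 by (4-bromophenyl)sulfonyl in place of (furan-2-yl)carbonyl on a nitrogen on an aromatic ring. Among the measured compounds shown here, the one measured step speaks to this change only in part: it shows that a 4-chlorophenyl on the carbonyl carbon gives a lower number than a furan-2-yl, and compound 3 again carries a halogenated phenyl, though now on a sulfonyl rather than a carbonyl. For the measured compounds named here, no measured pair tells how a sulfonyl compares with a carbonyl at this nitrogen, so that part of the change remains unknown.

Compound 3 is accordingly expected to show a step of a 6.0-fold lower number from compound 2 to compound 3 (0.78 log units; beyond the scatter) in this assay, a decrease because compound 1 gives 3000 nM with its halogenated phenyl. The estimate for compound 3 is 5000 nM, within a range from 1000 nM to 30000 nM.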

Compound 3, half-maximal inhibitory concentration: 9850 nM
Compound 3: middle estimate off by 2.0-fold (0.29 log units), on the low side; low and high end bracket the measured number.
By their numbers in this assay, from the lowest: compound 1; then compound 3; then compound 2.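

At this nitrogen on an aromatic ring, replacing (furan-2-yl)carbonyl with (4-bromophenyl)sulfonyl gives a 3.0-fold lower number from compound 2 to compound 3 (0.48 log units; beyond the scatter) in this assay, so a halogenated phenyl group gives a lower number than the furan-containing group on a sulfonyl as well as on a carbonyl, and none of the three compounds goes against this. The change from the chlorophenyl amide gives a 3.3-fold higher number from compound 1 to compound 3 (0.52 log units; beyond the scatter), so the sulfonyl compound lies between the two amides, although this step alters both the halogen and the link to the nitrogen and cannot assign the difference to either one. No evidence is available to explain these differences.

The compounds shown leave open how sulfonyl and carbonyl compare with the aryl group held constant, a question that (4-chlorophenyl)sulfonyl or (4-bromophenyl)carbonyl on the same nitrogen would address directly. They also leave open whether the halogen itself matters, as an unsubstituted phenyl on either link would show, and how a non-aromatic group such as a piperidine or a longer alkyl chain would read at this position.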